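A few compounds are considered here, and "the series" means these few. Any claim that something is new, unique, unknown or untested is made for them only; others in the source may bear on it.

Three compounds share one core, and only one of them has a number. Compound 1 `CCOC(=O)c1sc(-c2cccc(NC(=O)c3ccc(Cl)cc3)c2)nc1Nc1ccc(N2CCN(C)CC2)cc1` gives "not determined" (no result reported) in a functional assay on Ramos cells (Homo sapiens) for antiproliferative activity, read by CCK-8 assay, with a stated time of 72 h; on this read-out lower numbers stand for stronger inhibition and higher numbers for weaker inhibition. Among the measured compounds shown here, compound 2 `CCOC(=O)c1sc(-c2cccc(NC(=O)c3ccc(F)c(Cl)c3)c2)nc1Nc1ccc(N2CCN(C)CC2)cc1`, measured in this assay, gives 29200 nM, a weak result on its own and the only value available here. Compound 3 `CCOC(=O)c1sc(-c2cccc(NC(=O)c3ccc(C(F)(F)F)cn3)c2)nc1Nc1ccc(N2CCN(C)CC2)cc1` likewise gives "not determined" (no result reported) in this assay. Compound 2 therefore stands alone on the numbers shown, and no comparison between measured compounds can be drawn from this set.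

The next compound, compound 4 `CN1CCN(c2ccc(Nc3nc(-c4cccc(NC(=O)c5ccc(F)c(Cl)c5)c4)sc3C(N)=O)cc2)CC1`, is built from compound 2 by a single change: amino in place of ethoxy on a carbonyl carbon. Put another way, the ethoxycarbonyl becomes a carbamoyl. For the measured compounds named here, nothing among the measured compounds shows how this kind of change behaves in this assay, so the expectation rests on the size of the change alone. A small step is expected from compound 2 to compound 4, a 1.9-fold lower number from compound 2 to compound 4 (0.29 log units; within the scatter), towards somewhat stronger inhibition, but not clearly beyond the usual scatter. Compound 4 is thus expected to reach about 15000 nM in this assay, with a range from 3000 nM to 70000 nM.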

Compound 4, half-maximal inhibitory concentration: 4830 nM
Compound 4: middle estimate off by 3.1-fold (0.49 log units), on the high side; the range from low to high includes it.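

Among the compounds shown here, this is the first pair in the set that differs in one place, so this position can now be read. Putting amino in place of ethoxy on a carbonyl carbon gives a 6.0-fold lower number from compound 2 to compound 4 (0.78 log units; beyond the scatter) in this assay and so moves the number towards stronger inhibition, by a modest step that lies beyond the scatter. Nothing available here explains why the change from ethoxycarbonyl to carbamoyl has this effect.

Still open, from the compounds shown here alone, is how other groups on this carbonyl carbon would behave, such as a carboxylic acid or a methylamino group. Steps involving compound 1 and compound 3 cannot be read, so it also remains unknown whether the same change would give a similar step with their different amide groups.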